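A few compounds are considered here, and "the series" means these few. Any claim that something is new, unique, unknown or untested is made for them only; others in the source may bear on it.

In an ADME assay on BHK-21 cells (Mesocricetus auratus) for cytotoxicity, read by MTT assay (a lower number here means that less compound is tolerated, a higher number that more compound is tolerated), the measured compounds so far are:

- Compound 1 `COc1ccc(-c2nc3cc(/C(C)=N/NC(N)=O)ccc3[nH]2)cc1`: "not determined" (no result reported)
- Compound 2 `COc1ccc(-c2nc3cc(/C(C)=N/NC(N)=S)ccc3[nH]2)cc1`: 13000 nM
- Compound 3 `COc1ccc(-c2nc3cc(/C(C)=N/NC(N)=S)ccc3[nH]2)c(OC)c1`: 28000 nM

Only two of these compounds have a number to compare. Compound 2 gives the lower of the two at 13000 nM, and compound 3 stands at 28000 nM. Compound 1 offers no guidance here.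

The next compound to be tested is compound 4 `C/C(=N\NC(N)=S)c1ccc2[nH]c(C3CCCCC3)nc2c1`. It keeps the rest of compound 2 but carries cyclohexyl in place of 4-methoxyphenyl on an aromatic carbon. The aromatic ring of carbon only thus gives way to a non-aromatic one.

Among the measured compounds shown here, one measured step bears on this change, and only loosely. Methoxy in place of hydrogen on an aromatic carbon gave a 2.2-fold higher number from compound 2 to compound 3 (0.33 log units; beyond the scatter), which is modest and just beyond the usual scatter. For the measured compounds named here, that step alters a substituent on the ring, whereas compound 4 swaps the whole ring, and no measured pair shows such a swap. The data therefore give little hint of direction, and only a small rise in this assay is expected. The estimated change is a 1.4-fold higher number from compound 2 to compound 4 (0.14 log units; within the scatter), and it may not clear the scatter.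

For compound 4, the expected value is 18000 nM, with an estimated range from 6000 nM to 60000 nM.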

Compound 4, half-maximal cytotoxic concentration: 24000 nM
Compound 4: the middle estimate sits 1.3-fold (0.12 log units) below what was measured, and the stated range covers the measured number.
By their numbers in this assay, from the lowest: compounds 2, 4 and 3 (each within the scatter of the next, the first and the last beyond it).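

Among the compounds shown here, this is the first view in this assay of what happens when the whole 4-methoxyphenyl group is exchanged on the aromatic carbon between two ring nitrogen atoms, rather than a substituent being added to its ring. With cyclohexyl in its place, the change amounts to a 1.8-fold higher number from compound 2 to compound 4 (0.27 log units; within the scatter) and so does not separate the two compounds, even though the entering six-membered ring is non-aromatic, has fewer heavy atoms and has no hydrogen-bond acceptor. The data offer no measured property that could explain this result.

On these data alone, it remains open whether this position needs a ring at all, and a plain butyl chain or a pyridyl ring, which holds a nitrogen, would help to answer that. Also open is how the number in this assay would respond to an amine or a carboxylic acid attached to the cyclohexyl ring, as neither group appears among the compounds shown.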